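This account rests on a few compounds, and the source may have more. Where it says the series, first, only, none or still open, it means among the compounds named here.

In an ADME assay on Vero C1008 cells (Chlorocebus sabaeus) for cytotoxicity (on this read-out higher numbers stand for lower toxicity in this test and lower numbers for higher toxicity in this test), three compounds built on one shared core have been measured. Compound 1 `COC(=O)/C=C/CNC(=O)c1cccc2c1NC(C)(C)C=C2C` gives 6700 nM. Compound 2 `COC(=O)CCCNC(=O)c1cccc2c1NC(C)(C)C=C2C` reaches only the limit of the test, reported as > 30000 nM. Compound 3 `COC(=O)CCCNC(=O)c1cccc2c1NC(C)(C)C[C@H]2C` also stops at a limit, reported as > 30000 nM. Between the two measured numbers there is one step, an at least 4.4-fold lower number from compound 2 to compound 1 (0.65 log units; beyond the scatter), and it comes from a single change: 2-(methoxycarbonyl)ethenyl in place of 2-(methoxycarbonyl)ethyl on a saturated chain carbon bound to an amide-type nitrogen. How the core of compound 3 differs from that of compound 2 is not broken down here. Compound 4 `COC(=O)/C=C/CNC(=O)c1cccc2c1NC(C)(C)C[C@H]2C` has not yet been tested in this assay. It differs from compound 3 by 2-(methoxycarbonyl)ethenyl in place of 2-(methoxycarbonyl)ethyl on a saturated chain carbon bound to an amide-type nitrogen, which is the same change that separates compound 2 from compound 1, at the same place. The values of compound 2 and compound 3 both sit at the limit of > 30000 nM in this assay, at which 2 of the 3 values shown sit, so the starting point for compound 4 is known only as a bound. A step of about an at least 4.0-fold lower number from compound 3 to compound 4 (0.60 log units; beyond the scatter) is expected, resting on the measured step of an at least 4.4-fold lower number from compound 2 to compound 1 (0.65 log units; beyond the scatter). On that basis compound 4 is estimated at 7500 nM in this assay, expected to fall between 2500 nM and 30000 nM.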

Compound 4, half-maximal cytotoxic concentration: > 30000 nM
Compound 4: a limit, no number (the forecaster's own chance of this, stated with the estimate: 25%); at least 4.0-fold (0.60 log units) between middle value and limit.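

No new step can be read from compound 3 to compound 4, since in this assay both compounds stop at a limit and give no number: the limit of > 30000 nM in this assay, at which 3 of the 4 values shown sit.

The compounds shown leave open whether 2-(methoxycarbonyl)ethenyl in place of 2-(methoxycarbonyl)ethyl changes the number at all on the core of compound 3, as it does from compound 2 to compound 1.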